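Adding a Phenyl to the Hydroxy Side Chain of Compound 3

The source may report more compounds than this note shows. Statements on the series, on what has been measured and on what is new or still open speak of the compounds shown alone.

For the measured compounds named here, compound 3 `COc1cc2nc(N3CCC(OCC(C)(C)O)CC3)nc(N)c2cc1OC` gives 1.28 nM in an assay on brain for displacement of a labelled ligand from Adrenergic receptor alpha-1 (Rattus norvegicus) (a lower number here means a stronger inhibitor, a higher number a weaker inhibitor), the second highest of the three numbers measured so far: near compound 1 `COCCOC1CCN(c2nc(N)c3cc(OC)c(OC)cc3n2)CC1` at 2.12 nM, and further from compound 2 `COc1cc2nc(N3CCC(OCCOc4ccccc4)CC3)nc(N)c2cc1OC` at 0.48 nM. Compound 4 `COc1cc2nc(N3CCC(OCC(O)c4ccccc4)CC3)nc(N)c2cc1OC` carries hydroxy(phenyl)methyl in place of 1-hydroxy-1-methylethyl on a saturated chain carbon bound to an oxygen on a saturated carbon. Going by the values given here, two measured steps bear on this change: a 4.4-fold lower number from compound 1 to compound 2 (0.65 log units; beyond the scatter), and a 2.7-fold higher number from compound 2 to compound 3 (0.43 log units; beyond the scatter). In both, the compound bearing a phenyl gave the lower number. Compound 4 keeps the hydroxy group of compound 3 while adding the phenyl, so a modest lowering is expected, a 2.1-fold lower number from compound 3 to compound 4 (0.33 log units; beyond the scatter). The estimate for compound 4 is therefore 0.6 nM, with a range of 0.25 nM to 1.5 nM.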

Compound 4, inhibition constant: 0.15 nM
Estimate against measurement, compound 4: 4.0-fold (0.60 log units) above; the measured number lies below the stated range.
By their numbers in this assay, from the lowest: compound 4; then compound 2; then compounds 3 and 1 (each within the scatter of the next).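

In this assay, hydroxy(phenyl)methyl on this saturated chain carbon gives the lowest number of the series, with steps beyond the scatter against all three earlier compounds (an 8.5-fold lower number from compound 3 to compound 4 (0.93 log units; beyond the scatter); a 3.2-fold lower number from compound 2 to compound 4 (0.51 log units; beyond the scatter); a 14-fold lower number from compound 1 to compound 4 (1.15 log units; beyond the scatter)). Compound 2 also carries a phenyl, so at this position a phenyl alone does not reach the number of compound 4, which bears the hydroxy group as well. Nothing at hand gives a reason for this gain. On these data alone, whether an amine or a methoxy group could replace that hydroxy group remains open, as does the effect of a longer chain between the phenyl and the oxygen on the saturated carbon.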